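The source may hold more compounds than are shown below. What is called first, only, known or untested is meant among the compounds shown, and "the series" means these compounds.

Compound 1 `CCSC(=S)SCC(=O)c1cccc(S(=O)(=O)Nc2cccc(C(N)=O)c2)c1` and compound 2 `CCSC(=S)SCC(=O)c1cccc(NC(C)=O)c1` share a core that carries an ethyl trithiocarbonate chain ending in a ketone, and both were tested in an assay on HEK293 cells for inhibition of protein deacetylase HDAC6 (Homo sapiens); on this read-out higher numbers stand for weaker inhibition and lower numbers for stronger inhibition. Compound 1 gives 181 nM in this assay, and compound 2 gives 329 nM. Among the compounds with values here, of the two numbers, the one for compound 1 is the lower, but its gap to compound 2 lies within the usual scatter, so the two cannot be ranked against each other.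

Compound 3 `CCSC(=S)SCC(=O)c1cccc(S(=O)(=O)Nc2ccc(OC)cc2)c1` has not yet been measured in this assay. It differs from compound 1 in one place: 4-methoxyphenyl in place of 3-carbamoylphenyl on a sulfonamide nitrogen. With this change the hydrogen-bond donor of the 3-carbamoylphenyl group is lost, and the group that enters is slightly smaller.

Within the data shown here, no measured pair shows what this particular change does, so the expectation rests only on the two numbers at hand. For compound 3 a small step towards weaker inhibition is expected, expressed as a 1.8-fold higher number from compound 1 to compound 3 (0.25 log units; within the scatter), a step that could still fall within the scatter. Compound 3 is therefore estimated at 320 nM in this assay, with a likely range from 120 nM to 900 nM.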

Compound 3, half-maximal inhibitory concentration: 519 nM
Compound 3: the middle estimate sits 1.6-fold (0.21 log units) below what was measured; the range from low to high includes it.
By their numbers in this assay, from the lowest: compounds 1, 2 and 3 (each within the scatter of the next, the first and the last beyond it).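

The group on the sulfonamide nitrogen does make a measurable difference in this assay: 4-methoxyphenyl in place of 3-carbamoylphenyl gives a 2.9-fold higher number from compound 1 to compound 3 (0.46 log units; beyond the scatter), a modest step but one that clearly exceeds the noise of the measurement. Compounds 1 and 2 differ in more than one place, so they could not show the effect of any single change, whereas this pair isolates one group on an otherwise shared structure. The counts show that 3-carbamoylphenyl carries a hydrogen-bond donor and 4-methoxyphenyl carries none, but no accompanying measurement links that difference, or any other, to the weaker inhibition, so the step remains without an explanation.

This single swap replaces one group with another that differs in several ways, so the compounds shown cannot separate the loss of the carbamoyl group from the arrival of the methoxy group. They also leave open how an unsubstituted phenyl group, or a phenyl ring bearing a carboxylic acid or an amine, would behave on the same sulfonamide nitrogen.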